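Swapping the aryl group on the shared core

The source may report more compounds than this note shows. Statements on the series, on what has been measured and on what is new or still open speak of the compounds shown alone.

Among the measured compounds shown here, in a functional assay on MCF7 cells (Homo sapiens) for inhibition (on this read-out lower numbers stand for stronger inhibition and higher numbers for weaker inhibition), compound 2 `CC/C(=C(/c1ccc(/C=C/C(=O)O)cc1)c1cc2ccccc2[nH]1)c1cc(Cl)ccc1Cl` gives 71 nM, while compound 1 `CC/C(=C(/c1ccc(/C=C/C(=O)O)cc1)c1cc2ccccc2[nH]1)c1cccc(C)c1` gives 140 nM; the only measured step, a 2.0-fold lower number from compound 1 to compound 2 (0.29 log units; within the scatter), also exchanged this aryl group. Compound 3 `CC/C(=C(/c1ccc(/C=C/C(=O)O)cc1)c1cc2ccccc2[nH]1)c1ccc(Cl)c(C)c1` differs from compound 2 by 4-chloro-3-methylphenyl in place of 2,5-dichlorophenyl on a double-bonded chain carbon bound to a double-bonded chain carbon and a saturated chain carbon. Because that single prior step of this kind, a 2.0-fold lower number from compound 1 to compound 2 (0.29 log units; within the scatter), stayed within the scatter, no step beyond the scatter is expected for compound 3 in this assay, with a 1.3-fold higher number from compound 2 to compound 3 (0.10 log units; within the scatter) as the expected change. Compound 3 is therefore estimated at 90 nM, within a range from 35 nM to 250 nM.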

Compound 3, half-maximal inhibitory concentration: 840 nM
Compound 3: middle estimate off by 9.3-fold (0.97 log units), on the low side; the measured number lies above the stated range.
By their numbers in this assay, from the lowest: compounds 2 and 1 (each within the scatter of the next); then compound 3.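

In this assay this position proved far less tolerant than the first pair suggested: the aryl exchange gave a 12-fold higher number from compound 2 to compound 3 (1.07 log units; beyond the scatter) and so moved the number well beyond the scatter. Chloro in place of hydrogen on an aromatic carbon of the 3-methylphenyl group gave a 6.0-fold higher number from compound 1 to compound 3 (0.78 log units; beyond the scatter) as a single change, so that one addition is enough for a step beyond the scatter. No measured evidence bears on the cause of this loss. The compounds shown leave open how a fluoro or methoxy group would read in place of that chloro, and how a 4-chlorophenyl group without the methyl would read.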